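Chloromethyl versus diazomethyl ketones on a farnesyl-thioether scaffold

The source may report more compounds than this note shows. Statements on the series, on what has been measured and on what is new or still open speak of the compounds shown alone.

Two compounds in this series have numbers in a functional assay on NALM-6 cells (Homo sapiens); a lower number here means a stronger inhibitor, a higher number a weaker inhibitor. Compound 1 `CC(C)=CCC/C(C)=C/CC/C(C)=C/CSC[C@H](NC(=O)OC(C)(C)C)C(=O)CCl` gives 10700 nM. Compound 2 `CC(C)=CCC/C(C)=C/CC/C(C)=C/CSC[C@H](NC(=O)CNC(=O)OC(C)(C)C)C(=O)C=[N+]=[N-]` gives 51300 nM; this is the highest of the two numbers, and compound 1, the nearest neighbour, sits at a lower number, the gap lying beyond the scatter. The two compounds differ in more than one place, so the two values only show that compound 2 is the weaker of the pair.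

Compound 3 `CC(C)=CCC/C(C)=C/CC/C(C)=C/CSC[C@H](NC(=O)CNC(=O)OC(C)(C)C)C(=O)CCl` has not been measured. It differs from compound 2 by a group of 2 heavy atoms (1 carbon, 1 chlorine; no ring) in place of a group of 3 heavy atoms (1 carbon, 2 nitrogen; no ring), on a carbonyl carbon; everything else, including the glycine spacer carrying the carbamate, is shared. For the measured compounds named here, no measured step isolates this exchange. Going by the values given here, the only guide is that compound 1, which also carries the chloromethyl ketone, gives 10700 nM.

The expectation is a step toward a lower number, of about a 3.4-fold lower number from compound 2 to compound 3 (0.53 log units; beyond the scatter), beyond the scatter. Compound 3 is therefore estimated at 15000 nM, with a range from 4000 nM to 55000 nM.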

Compound 3, half-maximal inhibitory concentration: 12900 nM
Compound 3: middle estimate off by 1.2-fold (0.07 log units), on the high side; the range from low to high includes it.
By their numbers in this assay, from the lowest: compounds 1 and 3 (each within the scatter of the next); then compound 2.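

In this assay, for the compounds shown here, chloromethyl in place of the diazo-bearing group on a carbonyl carbon gives a 4.0-fold lower number from compound 2 to compound 3 (0.60 log units; beyond the scatter), a modest step and the first reading of this exchange with the glycine spacer and carbamate held constant. With the chloromethyl ketone held constant, ((tert-butoxycarbonyl)amino)methyl in place of tert-butoxy on a carbonyl carbon gives a 1.2-fold higher number from compound 1 to compound 3 (0.08 log units; within the scatter), so compounds 1 and 3 cannot be told apart, and within these three compounds the ketone exchange alone gives a step beyond the scatter. No measurement at hand accounts for either reading.

On these data alone, the exchange has been read only on the glycine-spacer scaffold, so it remains open whether a diazomethyl ketone would stand apart from compound 1 by a similar step, and whether a bromomethyl or fluoromethyl group on the same carbonyl carbon would read like chloromethyl. Also open, as far as these compounds go, is how the series would respond to a longer chain in place of the glycine spacer, or to a free amine in place of the carbamate.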